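The source may report more compounds than this note shows. Statements on the series, on what has been measured and on what is new or still open speak of the compounds shown alone.

Measured compounds and their values:

Compound 1, `Cc1ccc(NC(=O)c2cccc(/C=C3\CC(=O)N(c4ccccc4)C3=O)c2)cc1C`. In an ADME assay on HCT-116 cells (Homo sapiens) for cytotoxicity, read by MTT assay, with a stated time of 72 h (a lower number here means a stronger inhibitor, a higher number a weaker inhibitor), compound 1 gives only a limit, > 100000 nM.
Compound 2, `O=C(Nc1ccc(Cl)cc1)c1cccc(/C=C2\CC(=O)N(c3ccccc3)C2=O)c1`. In this assay compound 2 likewise gives only a limit, > 100000 nM.
Compound 3, `CSc1cccc(NC(=O)c2cccc(/C=C3\CC(=O)N(c4ccccc4)C3=O)c2)c1`. In this assay compound 3 gives 65200 nM.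

Going by the values given here, compound 3 thus holds the only real number among the three; the other two sit at the limit of the assay, (the limit of > 100000 nM in this assay, at which 2 of the 3 values shown sit). The step from the 3,4-dimethylphenyl compound to compound 3 reads an at least 1.5-fold lower number from compound 1 to compound 3 (0.18 log units; that floor lies within the scatter), and the step from the 4-chlorophenyl compound to compound 3 reads an at least 1.5-fold lower number from compound 2 to compound 3 (0.18 log units; that floor lies within the scatter); both are floors, and each floor lies within the scatter. Between compound 1 and compound 2 the two limits leave the step unreadable, a step that the two limits leave unreadable from compound 1 to compound 2.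

The next compound, compound 4, `CCc1ccc(NC(=O)c2cccc(/C=C3\CC(=O)N(c4ccccc4)C3=O)c2)cc1`, carries the change (4-ethylphenyl in place of 3-(methylsulfanyl)phenyl on an amide-type nitrogen). The 4-ethylphenyl group brings compound 4 closer to the amide-side groups of compound 1 and compound 2 than to that of compound 3. Both steps toward compound 3 were lowerings of at least the stated floor, so the reverse move is expected to raise the number in this assay, though by an amount that may not exceed the scatter. Compound 4 is therefore estimated at 95000 nM, with a range from 40000 nM to 220000 nM, an expected step of a 1.5-fold higher number from compound 3 to compound 4 (0.16 log units; within the scatter), and a real chance that only a limit is reported.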

Compound 4, half-maximal inhibitory concentration: > 100000 nM
Compound 4 gave a limit, no number (the forecaster's own chance of this, stated with the estimate: 50%); middle value at least 1.0-fold (0.02 log units) away from the limit.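

In this assay, replacing 3-(methylsulfanyl)phenyl with 4-ethylphenyl on the amide-type nitrogen gives an at least 1.5-fold higher number from compound 3 to compound 4 (0.18 log units; that floor lies within the scatter), so this swap, which keeps the count of 8 heavy atoms in the group but exchanges its sulfur for carbon and loses its one hydrogen-bond acceptor, has not been shown to shift the read-out beyond the usual scatter. The steps linking compound 4 to compound 1 and compound 2 cannot be read, so the three groups other than 3-(methylsulfanyl)phenyl cannot be ranked against one another. A third group at this position now ends at the same limit, leaving compound 3 as the only compound with a real number: the limit of > 100000 nM in this assay, at which 3 of the 4 values shown sit.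

The compounds shown leave open how far compound 3 truly lies from the other three, and whether its sulfur or the place of its substituent on the phenyl ring accounts for its separate reading. They also leave open how this position would respond to an amine, a carboxylic acid or a longer chain such as butyl in place of ethyl.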